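Replacing the carbamate on the ring amine of compound 3

A few compounds are considered here, and "the series" means these few. Any claim that something is new, unique, unknown or untested is made for them only; others in the source may bear on it.

Of the compounds shown here, three have been measured in a functional assay on CHO-K1 cells for agonist activity at Glucose-dependent insulinotropic receptor (Homo sapiens), read by a luciferase reporter, with a stated time of 5 h; on this read-out lower numbers stand for an effect already at smaller amounts and higher numbers for an effect only at larger amounts of compound. Compound 1 `CC(C)(C)OC(=O)N1CCC(Oc2cccc3c2CCN3c2ccc(S(C)(=O)=O)cc2)CC1` gives 158 nM, and compound 2 `CC(C)OC(=O)N1CCC(Oc2ncnc3c2CCN3c2ccc(-c3cccn3C)cc2F)CC1` gives 158 nM. Compound 3 `CCCCOC(=O)N1CCC(Oc2ncnc3c2CCN3c2ccc(S(C)(=O)=O)cc2F)CC1` gives 50.1 nM, the lowest number of the three; its gap to compound 1 and to compound 2 lies beyond the scatter. No two of the measured compounds differ in only one place, so no single step can be read from them, and all three carry an alkoxycarbonyl group on the ring amine nitrogen.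

Compound 4 `CN(C)C(=O)CN1CCC(Oc2ncnc3c2CCN3c2ccc(S(C)(=O)=O)cc2F)CC1` is not yet measured. It differs from compound 3 as follows: (dimethylcarbamoyl)methyl in place of butoxycarbonyl on an amine nitrogen in a ring. Among the compounds with values here, the series holds no measured example of a (dimethylcarbamoyl)methyl group at this place, so the expectation rests only on compound 3 at 50.1 nM and on the size of the change. A step upward of moderate size is expected for compound 4, of about a 3.0-fold higher number from compound 3 to compound 4 (0.48 log units; beyond the scatter), though a result within the scatter would not surprise. In this assay compound 4 is estimated at 150 nM, with a range from 40 nM to 600 nM.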

Compound 4, half-maximal effective concentration: > 10000 nM
Compound 4: a limit, no number; the forecaster's own chance of this, stated with the estimate: 5%; middle value at least 66-fold (1.82 log units) away from the limit.
By their numbers in this assay, from the lowest: compound 3; then compounds 1 and 2 (each within the scatter of the next). At a limit, above all of these: compound 4.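

In this assay compound 4 gives > 10000 nM, which is a limit and not a number: the limit of > 10000 nM in this assay, at which 1 of the 4 values shown sits.

Placing (dimethylcarbamoyl)methyl in place of butoxycarbonyl on the amine nitrogen in the ring gives an at least 190-fold higher number from compound 3 to compound 4 (2.30 log units; beyond the scatter), the first step that can be read at this place. All earlier compounds carry an alkoxycarbonyl group here, so only now is it visible that the read-out at this nitrogen does not tolerate every replacement, even though the two groups are close in heavy-atom count.

Which part of the change carries the step stays open, and a urea, a simple acyl group or a plain alkyl chain on this nitrogen would help separate the parts. Also open, from the compounds shown here alone, is how a shorter or branched alkoxycarbonyl chain compares with butoxycarbonyl on the core of compound 3.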